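This account rests on a few compounds, and the source may have more. Where it says the series, first, only, none or still open, it means among the compounds named here.

Compound 1 `Cc1cc(C)c(CN2CCc3ccc(O[C@@H]4CCOC4)c(Cl)c3C2=O)c(=O)[nH]1`, compound 2 `Cc1cc(C)c(CN2CCc3c(F)cc(O[C@@H]4CCOC4)c(Cl)c3C2=O)c(=O)[nH]1` and compound 3 `Cc1cc(C)c(CN2CCc3c(Cl)cc(-c4cn[nH]c4)c(Cl)c3C2=O)c(=O)[nH]1` share one core and were tested in an assay on cells for inhibition of histone-lysine N-methyltransferase EZH2 (Homo sapiens), read by ELISA, with a stated time of 72 h; on this read-out higher numbers stand for weaker inhibition and lower numbers for stronger inhibition. Compound 2 gives 994 nM, a number within the scatter of compound 1 at 796 nM and of compound 3 at 1730 nM. Compound 4 `Cc1cc(C)c(CN2CCc3c(C)cc(O[C@@H]4CCOC4)c(Cl)c3C2=O)c(=O)[nH]1` has not yet been measured; it differs from compound 2 by methyl in place of fluoro on an aromatic carbon. Among the measured compounds shown here, the only measured step at this position, a 1.2-fold higher number from compound 1 to compound 2 (0.10 log units; within the scatter), stayed within the scatter, so small changes at this carbon have so far left the number essentially unchanged. The step from compound 2 to compound 4 is therefore expected to be a 1.1-fold lower number from compound 2 to compound 4 (0.04 log units; within the scatter), nothing beyond the scatter. Compound 4 is estimated at 900 nM, with a range from 400 nM to 2000 nM.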

Compound 4, half-maximal inhibitory concentration: 290 nM
Compound 4: the middle estimate sits 3.1-fold (0.49 log units) above what was measured; the whole stated range lies above it.
By their numbers in this assay, from the lowest: compound 4; then compounds 1, 2 and 3 (each within the scatter of the next, the first and the last beyond it).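

This carbon is less indifferent than the earlier pair suggested: in this assay methyl gives stronger inhibition than either fluoro or hydrogen, with a 3.4-fold lower number from compound 2 to compound 4 (0.53 log units; beyond the scatter) and a 2.7-fold lower number from compound 1 to compound 4 (0.44 log units; beyond the scatter) as the two steps. The group here can therefore move the number beyond the scatter, and the step from hydrogen to fluoro did not predict the step to methyl. No measurement here explains why methyl and fluoro differ.

As far as these compounds go, whether ethyl, methoxy or an amine on this carbon would give stronger or weaker inhibition than methyl remains open.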